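Working notes: amide change from compound 2 to compound 4

The source may report more compounds than this note shows. Statements on the series, on what has been measured and on what is new or still open speak of the compounds shown alone.

Measured so far, in an assay on cells for inhibition of cytochrome P450 11B2, mitochondrial (Homo sapiens), read by HTRF; on this read-out higher numbers stand for weaker inhibition and lower numbers for stronger inhibition:
compound 1 `CC1(C)c2cc(Cl)ccc2C(=O)N1c1cncc(OC2CN(C(=O)c3ncccc3Cl)C2)c1` gives 5 nM
compound 2 `CCC(=O)NCc1cncc(N2C(=O)c3ccc(Cl)cc3C2(C)C)c1` gives 282 nM
compound 3 `CC1(C)CN(c2cccnc2)C(=O)c2ccc(Cl)cc21` gives 1540 nM

Compound 2 stands second highest of the three numbers in this assay. Its nearest neighbour is compound 3, whose number is higher by a gap beyond the usual scatter; compound 1 is furthest from it, with a much lower number, again well beyond the scatter. Compound 2 and compound 3 share the same core; compound 1 carries an aromatic amide on a different linker and is the only one of the three with a low number.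

Compound 4 `Cc1cccnc1C(=O)NCc1cncc(N2C(=O)c3ccc(Cl)cc3C2(C)C)c1` differs from compound 2 in one place: 3-methylpyridin-2-yl in place of ethyl on a carbonyl carbon. Within the data shown here, no measured pair in this set isolates that change, so the size of the step rests on judgement. Among the measured compounds shown here, compound 1, the only measured compound bearing an aromatic amide, gives 5 nM in this assay, which gives some ground to expect a lower number for compound 4 rather than a higher one. The step from compound 2 to compound 4 is expected to be a 4.7-fold lower number from compound 2 to compound 4 (0.67 log units; beyond the scatter), a clear drop beyond the scatter but short of the level of compound 1. Compound 4 is therefore estimated at 60 nM, with a range from 15 nM to 250 nM.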

Compound 4, half-maximal inhibitory concentration: 9 nM
Compound 4: the middle estimate sits 6.7-fold (0.82 log units) above what was measured; the whole stated range lies above it.
By their numbers in this assay, from the lowest: compounds 1 and 4 (each within the scatter of the next); then compound 2; then compound 3.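

In this assay, among these compounds, 3-methylpyridin-2-yl in place of ethyl on the carbonyl carbon gives a 31-fold lower number from compound 2 to compound 4 (1.50 log units; beyond the scatter), the only step in this set that isolates a single change. It shows that activity in this series responds strongly to the group on this carbonyl carbon while the shared core and the amide-type nitrogen stay the same: going from propanoyl to (3-methylpyridin-2-yl)carbonyl adds one six-membered aromatic ring with one hetero atom and one hydrogen-bond acceptor, and the number falls by a large step. The data at hand offer no measurement that explains the size of this step.

This one pair cannot separate the contribution of the ring from that of its methyl, and pyridin-2-yl without the methyl, phenyl, or a longer alkyl chain such as butyl on the same carbonyl carbon would help to divide the step between them. It also leaves open how far the step depends on the amide hydrogen, which a methyl group on the amide-type nitrogen would test.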